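This account rests on a few compounds, and the source may have more. Where it says the series, first, only, none or still open, it means among the compounds named here.

Of the compounds shown here, two built on a shared amide core have so far been measured in a functional assay on the whole organism (integument) for inhibition, with Chilo suppressalis as the target, read by scintillation counting, with a stated time of 72 h; a higher number here means a weaker inhibitor, a lower number a stronger inhibitor. Compound 1 `O=C(Nc1nnc(-c2ccc(Cl)cc2)s1)c1ccccc1I` returns only a limit of the assay in this assay, > 5010 nM. Compound 2 `COc1cccc(OC)c1C(=O)Nc1nnc(-c2ccc(C)cc2)s1` gives 1230 nM in this assay. Within the data shown here, of the two values shown, only that of compound 2 is a number; the other sits at the limit (the limit of > 5010 nM in this assay, at which 1 of the 2 values shown sits). Among the measured compounds shown here, no two measured compounds differ in a single place, so no measured step is available to guide expectations.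

Compound 3 `COc1cccc(OC)c1C(=O)Nc1nnc(-c2ccc(F)cc2)s1` remains to be measured in this assay. It differs from compound 2 by fluoro in place of methyl on an aromatic carbon, para to a large group. For the measured compounds named here, with no measured step of this kind to draw on, the step from compound 2 to compound 3 in this assay is expected to stay within the usual scatter, leaning if anything toward slightly weaker inhibition, and is estimated as a 1.2-fold higher number from compound 2 to compound 3 (0.09 log units; within the scatter). Compound 3 is accordingly expected to show 1500 nM in this assay, with a range from 600 nM to 4000 nM.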

Compound 3, half-maximal inhibitory concentration: 97.7 nM
The estimate for compound 3 lay 15-fold (1.19 log units) above the measured number; the whole stated range lies above it.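

In this assay, the change from 4-methylphenyl to 4-fluorophenyl gives a 13-fold lower number from compound 2 to compound 3 (1.10 log units; beyond the scatter), a large step at an aromatic carbon para to a large group. The earlier compounds shown here offered no step in a single place, so only now can inhibition be seen to depend strongly on what sits at this position, even though methyl and fluoro each count one heavy atom and the rest of the molecule stays the same. The values shown give no measured property that would account for the size of this step.

From the compounds shown here alone, it remains open whether hydrogen, methoxy or trifluoromethyl at this position would read closer to compound 2 or to compound 3, and so whether the step reflects the arrival of fluoro or the loss of methyl. Compound 1 carries chloro at this position but also differs from compound 2 and compound 3 elsewhere, and its reading is a limit of the assay and not a number, so it does not settle the question: the limit of > 5010 nM in this assay, at which 1 of the 3 values shown sits.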